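Working notes on the aryl ketone replacement in this series

The source may hold more compounds than are shown below. What is called first, only, known or untested is meant among the compounds shown, and "the series" means these compounds.

Compound 1 `COc1cc(-c2cc(/C=C/C(=O)c3ccc(N)cc3)[nH]n2)cc(OC)c1OC` carries a 4-aminophenyl on the carbonyl carbon. In a functional assay on SN12C cells (Homo sapiens) for cytotoxicity, read by sulforhodamine B assay, with a stated time of 48 h, tested at 1 uM (a lower number here means a stronger effect, a higher number a weaker effect of the compound at the concentration tested), compound 1 gives 85%. Its nearest measured neighbour is compound 2 `COc1ccc(C(=O)/C=C/c2cc(-c3cc(OC)c(OC)c(OC)c3)n[nH]2)cc1`, which in this assay gives 91%. Going by the values given here, the only measured step, a number 6 percentage points higher from compound 1 to compound 2 (within the scatter), goes with methoxy in place of amino on an aromatic carbon and lies within the scatter, so compound 1 does not stand apart from compound 2 on the numbers so far.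

Compound 3 `COc1cc(-c2cc(/C=C/C(=O)c3ccc(F)c(F)c3)[nH]n2)cc(OC)c1OC` is not yet measured. Its difference from compound 1 is 3,4-difluorophenyl in place of 4-aminophenyl on a carbonyl carbon. Among the compounds with values here, no measured step exchanges the whole 4-aminophenyl or brings in fluorine, so the data give no direct precedent. Within the data shown here, the one step that alters the group on the carbonyl carbon, from compound 1 to compound 2, stayed within the scatter, and this is taken as the guide. The step expected in this assay is therefore small, a number 1 percentage points lower from compound 1 to compound 3 (within the scatter), with no direction that the data can support. Compound 3 is estimated at 84%, with a range from 62% to 100%.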

Compound 3, a percentage reported as activity, at one concentration (the size of the read-out at that concentration, not a potency): 89%
Beside the measured number, compound 3's estimate is 5 percentage points below it; low and high end bracket the measured number.
By their numbers in this assay, from the lowest: compounds 1, 3 and 2 (each within the scatter of the next).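

In this assay the change of the whole aryl group on the carbonyl carbon gives a number 4 percentage points higher from compound 1 to compound 3 (within the scatter) and, set against the 4-methoxyphenyl group, gives a number 2 percentage points lower from compound 2 to compound 3 (within the scatter) for the same exchange, so the result now covers a fluorinated group as well as the earlier amino-to-methoxy change. Compounds 1, 2 and 3 therefore lie within the scatter of one another with 4-aminophenyl, 4-methoxyphenyl or 3,4-difluorophenyl at this position, and the loss of the hydrogen-bond donor and acceptor counted on 4-aminophenyl goes with no step beyond the scatter. No evidence at hand bears on why these three groups give such close numbers.

Going by these compounds, all three compounds keep a phenyl ring on the carbonyl carbon, so it remains open whether a non-aromatic group such as cyclohexyl, a pyridyl ring or a phenyl carrying a carboxylic acid would move the number beyond the scatter. The read-out is also a single-concentration one, so these compounds leave open whether any difference among the three aryl groups would appear in a full concentration series.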